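The source may hold more compounds than are shown below. What is called first, only, known or untested is meant among the compounds shown, and "the series" means these compounds.

Working notes on the series. The shared core is shown by compound 1, `C=C[C@@](C)(/C=C/c1ccc(OS(=O)(=O)C(F)(F)F)cc1)CCC=C(C)C`. In an ADME assay on BJ cells (Homo sapiens) for cytotoxicity, with a stated time of 72 h (a lower number here means that less compound is needed, a higher number that more compound is needed for the effect), compound 1 gives > 36600 nM, which is a limit of the assay and not a number. Compound 2, `C=C[C@@](C)(/C=C/c1ccc(O)c(CO)c1)CCC=C(C)C`, differs from compound 1 only in the groups on the aromatic ring. In this assay compound 2 gives > 36600 nM, again a limit rather than a number. Compound 1 therefore stands at the limit of > 36600 nM in this assay, at which 2 of the 2 values shown sit; nothing in the two values shown places either compound apart from the other, so no order between them can be drawn.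

Compound 3, `C=C[C@@](C)(/C=C/c1ccc(Nc2ccc(Cl)c(Cl)c2)cc1)CCC=C(C)C`, is not yet measured. The change from compound 1 is (3,4-dichlorophenyl)amino in place of ((trifluoromethyl)sulfonyl)oxy on an aromatic carbon. For the measured compounds named here, no step between measured compounds is available, so the expectation rests on the two limits alone. Given that compound 1 sits at > 36600 nM, the step of an at least 1.4-fold lower number from compound 1 to compound 3 (0.16 log units; that floor lies within the scatter) is expected to be none beyond the scatter. For compound 3 the expected value is 25000 nM, with a range from 8000 nM to 70000 nM.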

Compound 3, half-maximal effective concentration: > 36600 nM
Compound 3: a limit, no number; the forecaster's own chance of this, stated with the estimate: 55%; middle value at least 1.4-fold (0.16 log units) away from the limit.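

In this assay compound 3 gives > 36600 nM, again a limit of the assay and not a number. No step can be read from compound 1 to compound 3, as both values stand at the same limit: the limit of > 36600 nM in this assay, at which 3 of the 3 values shown sit.

The compounds shown leave open whether any group on the shared core gives a number rather than a limit in this assay.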